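The source may report more compounds than this note shows. Statements on the series, on what has been measured and on what is new or still open speak of the compounds shown alone.

Compound 1 `ClCc1ccccc1Cn1cnc2c(Cl)nc(Cl)nc21`: 3470 nM
Compound 2 `ClCc1cccc(Cn2cnc3c(Cl)nc(Cl)nc32)c1`: 26900 nM
Compound 3 `Nc1nc(Cl)c2ncn(Cc3ccccc3CCl)c2n1`: 52500 nM

These three compounds were measured in a functional assay on 786-0 cells (Homo sapiens) for cytotoxicity, read by sulforhodamine B assay, with a stated time of 48 h; on this read-out lower numbers stand for stronger inhibition of growth and higher numbers for weaker inhibition of growth. Compound 3 differs from compound 1 in one place: amino in place of chloro on an aromatic carbon. That change brought a 15-fold higher number from compound 1 to compound 3 (1.18 log units; beyond the scatter). Compound 2 and compound 1 are built from the same atoms joined differently; the difference between the two cores is not broken down here. Compound 2 and compound 3 lie within the usual scatter of each other, while compound 1 gives a number that is lower than that of compound 2 by more than the scatter.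

Compound 4 `Nc1nc(Cl)c2ncn(Cc3cccc(CCl)c3)c2n1` has not yet been measured in this assay. It relates to compound 2 as compound 3 relates to compound 1: amino in place of chloro on an aromatic carbon, the same change at the same place. Because compound 1 showed a 15-fold higher number from compound 1 to compound 3 (1.18 log units; beyond the scatter), for compound 4 the expected step is a 13-fold higher number from compound 2 to compound 4 (1.11 log units; beyond the scatter), of the same size as the earlier one. Compound 4 is therefore estimated at 350000 nM, with a range from 90000 nM to 1200000 nM expected.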

Compound 4, concentration for total growth inhibition: 26300 nM
The estimate for compound 4 lay 13-fold (1.12 log units) above the measured number; the whole stated range lies above it.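

In this assay, amino in place of chloro on an aromatic carbon gave a 1.0-fold lower number from compound 2 to compound 4 (0.01 log units; within the scatter), so the large step seen on the core of compound 1 did not carry over to the core of compound 2. For the compounds shown here, the two steps differ by more than their scatter allows: the same change on two cores in this assay, a 15-fold higher number (1.18 log units; beyond the scatter) from compound 1 to compound 3 and a 1.0-fold lower number (0.01 log units; within the scatter) from compound 2 to compound 4, 15-fold (1.19 log units) apart, beyond the scatter of two such steps This shows that, in this pair of cores, which are built from the same atoms joined differently, the effect of the change cannot be transferred from one core to the other, but with only two cores it does not show which feature of the cores separates the outcomes or what the change would do on a third core.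

The compounds shown carry only chloro or amino at this carbon, so what a methylamino or methoxy group would give there remains open. All four also carry the chloromethyl group, leaving open how a hydroxymethyl or plain methyl group in its place would read.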